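Swapping Nitro for Methoxy in an Antiproliferative Series

A few compounds are considered here, and "the series" means these few. Any claim that something is new, unique, unknown or untested is made for them only; others in the source may bear on it.

- Compound 1 `COc1cc(C(=O)/C=C\Nc2ccc(-c3nc4cc(OC)c(OC)c(OC)c4s3)cc2)c(Br)c(OC)c1OC` gives 13600 nM in cell testing
- Compound 2 `COc1cc(C(=O)/C=C\Nc2ccc(-c3nc4cc(OC)c(OC)c(OC)c4s3)cc2)cc([N+](=O)[O-])c1OC` gives 11800 nM in cell testing

Both values come from a functional assay on A549 cells (Homo sapiens) for antiproliferative activity, read by sulforhodamine B assay, with a stated time of 48 h (on this read-out higher numbers stand for weaker inhibition and lower numbers for stronger inhibition), and lie within the usual scatter of each other. Compound 2 at 11800 nM therefore cannot be told apart from compound 1 at 13600 nM on these numbers.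

The next compound is compound 3 `COc1cc(C(=O)/C=C\Nc2ccc(-c3nc4cc(OC)c(OC)c(OC)c4s3)cc2)cc(OC)c1OC` and it differs from compound 2 in one place. The change is methoxy in place of nitro on an aromatic carbon with methoxy in place of nitro on an aromatic carbon. Among the compounds with values here, no measured pair isolates a single change, so the data give no direct guide to this swap. A modest move toward stronger inhibition is expected, near the edge of the scatter, starting from compound 2 at 11800 nM as the only close anchor. The expected change is a 2.0-fold lower number from compound 2 to compound 3 (0.29 log units; within the scatter) in this assay on this estimate. For compound 3 the estimated value is 6000 nM with an expected range from 1500 nM to 20000 nM on repeat measurement.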

Compound 3, half-maximal inhibitory concentration: 15500 nM
The estimate for compound 3 lay 2.6-fold (0.41 log units) below the measured number; the range from low to high includes it.
By their numbers in this assay, from the lowest: compounds 2, 1 and 3 (each within the scatter of the next).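

In this assay methoxy in place of nitro on this aromatic carbon gives a 1.3-fold higher number from compound 2 to compound 3 (0.12 log units; within the scatter) and hydrogen in place of bromo on an aromatic carbon gives a 1.1-fold higher number from compound 1 to compound 3 (0.06 log units; within the scatter) with both steps printed as within the scatter. Neither swap can therefore be told apart from no change at all, even though nitro and methoxy differ in their heavy atoms and hydrogen-bond acceptors. Nothing available here gives a reason for this result.

The compounds shown leave open whether an amine, a carboxylic acid or a longer chain such as ethoxy on this aromatic carbon would shift the number beyond the scatter. On these data alone, all three values also come from one cell test, so whether these swaps read the same way in other cells remains unknown.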